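Series notes: 4-methylpyridin-2-yl for 2,4-dichlorophenyl

The compounds below may be only part of what the source reports. "The series", "measured", "known", "first", "only" and "open" are said of these compounds alone.

Compound 1 `Clc1ccc(Nc2cc(N3CCNCC3)nc3ccnn23)c(Cl)c1` has been tested in an assay on isolated protein for inhibition of Dipeptidyl peptidase 9 (Homo sapiens); on this read-out higher numbers stand for weaker inhibition and lower numbers for stronger inhibition. The value for compound 1, > 100000 nM, is a limit of the assay and not a number. Compound 2 `N[C@@H]1CCCN(c2cc(NCc3ccccc3)n3nccc3n2)C1` in this assay gives > 100000 nM, which is likewise a limit. Compound 3 `Fc1ccc(CNc2cc(N3CCNCC3)nc3ccnn23)c(F)c1` in this assay gives > 50000 nM, again a limit. Compound 1 therefore stands at the limit of > 100000 nM in this assay, at which 2 of the 3 values shown sit. Compound 3 stands at the limit of > 50000 nM in this assay, at which 1 of the 3 values shown sits. Among the compounds with values here, no value among the three is a measured number, so no step between them can be sized.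

Compound 4 `Cc1ccnc(Nc2cc(N3CCNCC3)nc3ccnn23)c1` has not yet been measured. It differs from compound 1 by 4-methylpyridin-2-yl in place of 2,4-dichlorophenyl on a nitrogen on an aromatic ring. Because compound 1 sits at the limit of > 100000 nM in this assay, at which 2 of the 3 values shown sit, and the other values shown are also limits, the numbers give no direction for this change. For compound 4 the expected step is a number no higher from compound 1 to compound 4 (the limit leaves the size open), nothing beyond the usual scatter. Compound 4 in this assay is estimated at 100000 nM, with a range from 30000 nM to 300000 nM, and the assay is expected most likely to report only a limit again.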

Compound 4, half-maximal inhibitory concentration: > 100000 nM
Compound 4 gave a limit, no number; the forecaster's own chance of this, stated with the estimate: 80%; the middle value sits exactly at the limit.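

Compound 1 and compound 4 both give only a limit in this assay, so the step between them cannot be read: the limit of > 100000 nM in this assay, at which 3 of the 4 values shown sit.

The compounds shown leave open whether 2,4-dichlorophenyl or 4-methylpyridin-2-yl on the shared core gives stronger inhibition in this assay, and by how much.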